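The source may hold more compounds than are shown below. What is called first, only, known or untested is meant among the compounds shown, and "the series" means these compounds.

Compound 1 `COc1cc(/C=C/C(=O)c2cccc(-n3cc(-c4ccccc4)[nH]c3=O)c2)ccc1O`: 4160 nM
Compound 2 `O=C(/C=C/c1cccc(O)c1)c1cccc(-n2cc(-c3ccccc3)[nH]c2=O)c1`: 6140 nM

Both numbers come from a functional assay on Hs-578T cells (Homo sapiens) for inhibition; on this read-out lower numbers stand for stronger inhibition of growth and higher numbers for weaker inhibition of growth. Compound 1 has the lower of the two values, and its nearest neighbour is compound 2; the step between them, a 1.5-fold higher number from compound 1 to compound 2 (0.17 log units; within the scatter), means the two compounds cannot be told apart on this read-out.

Compound 3 `COc1ccc(-c2cn(-c3cccc(C(=O)/C=C/c4ccc(O)c(OC)c4)c3)c(=O)[nH]2)cc1` has not been measured. It differs from compound 1 in one place: methoxy in place of hydrogen on an aromatic carbon. The new group enters on an aromatic carbon of a six-membered aromatic ring of carbon only, para to a large group; read one bond further out, the change is phenyl to 4-methoxyphenyl.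

Among the measured compounds shown here, no measured step touches this part of the molecule. For the measured compounds named here, the only known step, from compound 1 to compound 2, alters the hydroxyphenyl at the far end of the chain, and it stayed within the scatter. There is nothing to point to a shift in either direction in this assay, so the expectation is a step no larger than the scatter. Compound 3 is expected to give about 4000 nM, with a range from 1500 nM to 11000 nM. The expected step is therefore a 1.0-fold lower number from compound 1 to compound 3 (0.02 log units; within the scatter).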

Compound 3, concentration for 50% growth inhibition: 4250 nM
For compound 3 the middle estimate is 1.1-fold (0.03 log units) below the measured one; measured number inside the range.
By their numbers in this assay, from the lowest: compounds 1, 3 and 2 (each within the scatter of the next).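

Placing methoxy on the aromatic carbon para to a large group, which turns phenyl into 4-methoxyphenyl, gives a step of a 1.0-fold higher number from compound 1 to compound 3 (0.01 log units; within the scatter) in this assay and leaves the two compounds indistinguishable on this read-out. Among the compounds shown here, this is the first measured change on this phenyl ring, as the earlier pair, compound 1 and compound 2, differed only in the hydroxyphenyl at the far end of the chain, and it shows that this aromatic carbon can carry methoxy with no readable difference in this assay. No separate measurement is available to explain this result.

As far as these compounds go, one small group at one place says little about the others, so it remains open whether a carboxylic acid, a dimethylamino group or a longer chain such as butoxy at this aromatic carbon would also leave the number within the scatter. From the compounds shown here alone, it also remains open whether methoxy would give the same result on another carbon of this ring, or whether this result would hold alongside a different group at the far end of the chain.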